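This account rests on a few compounds, and the source may have more. Where it says the series, first, only, none or still open, it means among the compounds named here.

Compound 1 `CCN(c1ccc(Cl)cc1C)S(=O)(=O)c1cc(Cl)ccc1Cl`, compound 2 `CCN(c1ccc(Cl)cc1F)S(=O)(=O)c1cc(Cl)ccc1Cl` and compound 3 `CCN(c1ccc(F)cc1F)S(=O)(=O)c1cc(Cl)ccc1Cl` share one core and differ only in the groups on the aniline ring. In an ADME assay on A549 cells (Homo sapiens) for cytotoxicity, read by MTT assay (on this read-out lower numbers stand for higher toxicity in this test and higher numbers for lower toxicity in this test), compound 1 gives > 5000 nM, which is a limit of the assay rather than a number. Compound 2 likewise gives > 5000 nM, a limit. Compound 3 also gives > 5000 nM, again a limit. The step that the two limits leave unreadable from compound 1 to compound 2 and the step that the two limits leave unreadable from compound 2 to compound 3 therefore cannot be read, because all three values sit at the limit of > 5000 nM in this assay, at which 3 of the 3 values shown sit. Compound 4 `CCN(c1c(F)cc(Cl)cc1F)S(=O)(=O)c1cc(Cl)ccc1Cl` differs from compound 2 by fluoro in place of hydrogen on an aromatic carbon. With no readable step among the measured compounds, the step that the limit leaves unreadable from compound 2 to compound 4 is expected to stay at the limit. Compound 4 is estimated at 8000 nM, within 4000 nM to 20000 nM.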

Compound 4, half-maximal cytotoxic concentration: > 5000 nM
Compound 4 gave a limit, no number; the forecaster's own chance of this, stated with the estimate: 85%; the middle value lies beyond the limit too.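

Compound 4, like compound 2, gives only a limit, so no new step can be read between them: the limit of > 5000 nM in this assay, at which 4 of the 4 values shown sit.

The compounds shown leave open what value any of them would reach in this assay, and whether any of these changes alters it.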